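The source may report more compounds than this note shows. Statements on the series, on what has been measured and on what is new or still open speak of the compounds shown alone.

Measured so far:
compound 1 `C=CCn1ncc2c(C)nc(CC)n2c1=O` — > 48000 nM
compound 2 `C=CCn1ncc2cncn2c1=O` — > 48000 nM

Both values in a functional assay for inhibition, with Homo sapiens as the target (a higher number here means a weaker inhibitor, a lower number a stronger inhibitor), are limits of the assay and not numbers. Compound 2 stands at the limit of > 48000 nM in this assay, at which 2 of the 2 values shown sit. For the measured compounds named here, no two measured compounds differ in a single place, so no measured step is available, and the two limits give no direction for any change on the shared core.

Compound 3 `C=CCn1ncc2c(C)ncn2c1=O` differs from compound 2 by methyl in place of hydrogen on an aromatic carbon. With both measured compounds reported only as limits, in this assay no step beyond the scatter is expected in either direction for this change. Compound 3 is expected to give 60000 nM, within 20000 nM to 200000 nM, and will most probably again be reported as a limit. The step expected is a step that the limit leaves unreadable from compound 2 to compound 3.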

Compound 3, half-maximal inhibitory concentration: > 48000 nM
Compound 3: only a limit was reported (the forecaster's own chance of this, stated with the estimate: 85%); the middle value is on the limit's open side.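

In this assay, for the compounds shown here, no step from compound 1 or compound 2 to compound 3 can be read, as all three results are limits and not numbers: the limit of > 48000 nM in this assay, at which 3 of the 3 values shown sit. The compounds shown leave open whether any change on the shared core gives a measurable inhibition value.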